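Chloro for Fluoro on the Benzyl Arm of Compound 3

The compounds below may be only part of what the source reports. "The series", "measured", "known", "first", "only" and "open" are said of these compounds alone.

The measured compounds, each with its value:
Compound 1 `O=C(NCc1cn(Cc2ccc(F)cc2)nn1)c1cn(-c2ccccc2)nc1-c1ccccc1` gives 1600 nM in a functional assay on HeLa cells (Homo sapiens) for antiproliferative activity, read by sulforhodamine B assay, with a stated time of 48 h; on this read-out lower numbers stand for stronger inhibition of growth and higher numbers for weaker inhibition of growth.
Compound 2 `O=C(NCc1cn(Cc2ccc(Cl)cc2)nn1)c1cn(-c2ccccc2)nc1-c1ccccc1` gives 600 nM in this assay.
Compound 3 `O=C(NCc1cn(Cc2ccc(F)cc2)nn1)c1cn(-c2ccccc2)nc1-c1ccc(F)cc1` gives 1200 nM in this assay.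

Compound 3 sits close to both neighbours: one step is a 1.3-fold lower number from compound 1 to compound 3 (0.12 log units; within the scatter), and the values of compound 3 and compound 2 lie within the usual scatter of each other, so no order among these three is secure apart from the step of a 2.7-fold lower number from compound 1 to compound 2 (0.43 log units; beyond the scatter).

Compound 4 `O=C(NCc1cn(Cc2ccc(Cl)cc2)nn1)c1cn(-c2ccccc2)nc1-c1ccc(F)cc1` differs from compound 3 by chloro in place of fluoro on an aromatic carbon. Going by the values given here, the one measured step of the same kind, a 2.7-fold lower number from compound 1 to compound 2 (0.43 log units; beyond the scatter), was modest but beyond the scatter. Carrying that step over to compound 3, compound 4 is expected to show a lower number in this assay by about a 2.7-fold lower number from compound 3 to compound 4 (0.43 log units; beyond the scatter). On that basis compound 4 is estimated at 450 nM, with a range from 200 nM to 1000 nM.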

Compound 4, concentration for 50% growth inhibition: 210 nM
Compound 4: middle estimate off by 2.1-fold (0.33 log units), on the high side, and the stated range covers the measured number.
By their numbers in this assay, from the lowest: compound 4; then compounds 2, 3 and 1 (each within the scatter of the next, the first and the last beyond it).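

The change from 4-fluorobenzyl to 4-chlorobenzyl now has a second reading, on the core carrying the 4-fluorophenyl group, where this assay gives a 5.7-fold lower number from compound 3 to compound 4 (0.76 log units; beyond the scatter). The change therefore goes the same way on both cores, and its two sizes cannot be told apart: the same change on two cores in this assay, a 2.7-fold lower number (0.43 log units; beyond the scatter) from compound 1 to compound 2 and a 5.7-fold lower number (0.76 log units; beyond the scatter) from compound 3 to compound 4, 2.1-fold (0.33 log units) apart, within the scatter of two such steps. The 4-fluorophenyl group, whose first step was a 1.3-fold lower number from compound 1 to compound 3 (0.12 log units; within the scatter), also gains a step beyond the scatter on the 4-chlorobenzyl side, a 2.9-fold lower number from compound 2 to compound 4 (0.46 log units; beyond the scatter), but this does not show that the two changes depend on each other: the same change on two cores in this assay, a 1.3-fold lower number (0.12 log units; within the scatter) from compound 1 to compound 3 and a 2.9-fold lower number (0.46 log units; beyond the scatter) from compound 2 to compound 4, 2.1-fold (0.33 log units) apart, within the scatter of two such steps.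

The compounds shown leave open how a bromo, methyl or methoxy group would read at this position on the benzyl arm. They also leave open whether an amine or a carboxylic acid there would keep the lower numbers seen with chloro.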